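The compounds below may be only part of what the source reports. "The series", "measured", "known", "first", "only" and "open" are said of these compounds alone.

In a functional assay on MCF7 cells (Homo sapiens) for inhibition, read by fluorescence, with a stated time of 72 h (on this read-out lower numbers stand for stronger inhibition and higher numbers for weaker inhibition), compound 1 `CC(C)n1cnc2c(NC(=N)N)nc(N)nc21` gives 97200 nM, while compound 2 `CC(C)n1cnc2c(NC(=N)N)nc(NCCO)nc21` gives 12400 nM. Compound 2 therefore holds the lower of the two numbers, and the gap lies beyond the usual scatter. Compound 3 `CC(C)n1cnc2c(NC(=N)N)nc(NCCCO)nc21` differs from compound 2 in one place: hydroxymethyl in place of hydroxy on a saturated chain carbon, two bonds along the chain from a nitrogen on an aromatic ring. This puts hydroxymethyl in place of hydroxy on a saturated chain carbon, two bonds along the chain from a nitrogen on an aromatic ring, so 2-hydroxyethyl becomes 3-hydroxypropyl. Going by the values given here, only one measured step bears on this: a 7.8-fold lower number from compound 1 to compound 2 (0.89 log units; beyond the scatter), where 2-hydroxyethyl replaced hydrogen. Among the compounds with values here, no measured pair yet compares chain lengths, so the direction is uncertain. Extending an existing chain is a smaller edit than adding one, so only a small step is expected, leaning slightly lower: a 1.2-fold lower number from compound 2 to compound 3 (0.09 log units; within the scatter). For compound 3 the estimated value is 10000 nM, within a range of 4000 nM to 28000 nM.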

Compound 3, half-maximal inhibitory concentration: 8800 nM
Compound 3: middle estimate off by 1.1-fold (0.06 log units), on the high side; low and high end bracket the measured number.
By their numbers in this assay, from the lowest: compounds 3 and 2 (each within the scatter of the next); then compound 1.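

In this assay the exchange of 2-hydroxyethyl for 3-hydroxypropyl gives a 1.4-fold lower number from compound 2 to compound 3 (0.15 log units; within the scatter) and cannot be told apart from repeat-measurement noise, so the extra carbon in this chain makes no readable difference. Measured against compound 1, which carries only hydrogen on that nitrogen, the longer chain gives an 11-fold lower number from compound 1 to compound 3 (1.04 log units; beyond the scatter) and so keeps the clear drop in the number first seen with 2-hydroxyethyl. No independent evidence explains either result.

Still open, from the compounds shown here alone, is how far the chain can grow, as 4-hydroxybutyl or a longer chain would show. Also open, going by these compounds, is whether the hydroxy itself is needed, which a plain propyl chain, or an amine or a carboxylic acid at the chain end, would test.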